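A few compounds are considered here, and "the series" means these few. Any claim that something is new, unique, unknown or untested is made for them only; others in the source may bear on it.

Measured so far:
- compound 1, `O=C(N/N=C/c1ccccc1O)c1ccc(-c2ccc(F)cc2)o1`: 13.1%
- compound 2, `COc1ccccc1C(=O)N/N=C/c1ccc(-c2ccc(F)cc2F)o1`: 7.77%

The numbers come from a functional assay on HL-60 cells (Homo sapiens) for inhibition, read by MTT assay, with a stated time of 48 h, tested at 10 uM (a higher number here means more inhibition of growth at the concentration tested, a lower number less inhibition of growth), in which compound 1 gives 13.1% and compound 2 gives 7.77%. Compound 1 carries the larger of the two numbers, but the gap to compound 2 lies within the usual scatter of this kind of measurement, so the two compounds cannot be told apart on these data; both show only modest growth inhibition at the tested concentration. Compound 2 also differs from compound 1 in more than one place, so no single structural change can be tied to the small difference between them.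

Compound 3, `O=C(N/N=C/c1ccc(O)cc1)c1ccc(-c2ccc(F)cc2)o1`, is the next compound, and it has not yet been measured in this assay. It differs from compound 1 in one place only: 4-hydroxyphenyl in place of 2-hydroxyphenyl on a carbon with a double bond to nitrogen. The same atoms are present in both, only arranged differently on the phenyl ring. Within the data shown here, no step between measured compounds shows what such a move of the hydroxyl group does here, so there is nothing to anchor a direction. The expectation is therefore a step from compound 1 to compound 3 of about a number 1.1 percentage points lower from compound 1 to compound 3 (within the scatter) in this assay, that is, no change beyond the scatter. Compound 3 is estimated to give 12% in this assay, with a likely range from 2% to 26%.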

Compound 3, percent growth inhibition at one concentration: 1.07%
Compound 3: middle estimate off by 10.9 percentage points, on the high side; measured number below the stated range.
By their numbers in this assay, from the lowest: compounds 3, 2 and 1 (each within the scatter of the next, the first and the last beyond it).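

In this assay, among these compounds, putting 4-hydroxyphenyl in place of 2-hydroxyphenyl on a carbon with a double bond to nitrogen gives a number 12 percentage points lower from compound 1 to compound 3 (beyond the scatter), which is the first single change in this set that can be read on its own. The two groups contain the same atoms and differ only in how those atoms are arranged on the phenyl ring, so this pair shows that the arrangement alone can shift the reading at this position, even though compound 1 itself inhibits growth only modestly at the tested concentration. No measurement available here explains why this rearrangement lowers the number.

On these data alone, it remains open whether a different group at this position, such as an aminophenyl or a carboxyphenyl group, would raise the number above that of compound 1 or lower it towards that of compound 3. Also unresolved is whether the same move of the hydroxyl group would have a similar effect on a compound with another group on the far side of the shared core, or at other concentrations.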